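Selenium Returns with a Hydroxyl in Place of Bromine

The source may report more compounds than this note shows. Statements on the series, on what has been measured and on what is new or still open speak of the compounds shown alone.

The measured compounds:
compound 1, `OCC#CCSc1cnc2ccccc2c1[Se]CC#CCBr`, 0.2 ug/mL in a functional assay on CCRF-CEM cells (Homo sapiens) for cytotoxicity, read by sulforhodamine B assay, with a stated time of 72 h; on this read-out higher numbers stand for weaker inhibition and lower numbers for stronger inhibition
compound 2, `OCC#CCSc1cnc2ccccc2c1SCC#CCBr`, 0.6 ug/mL in this assay

Compound 2 holds the higher of the two numbers in this assay; its nearest neighbour is compound 1, whose number is lower by a 3.0-fold higher number from compound 1 to compound 2 (0.48 log units; beyond the scatter).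

Compound 3, `OCC#CCSc1cnc2ccccc2c1[Se]CC#CCO`, has not yet been measured. It differs from compound 2 as follows: a group of 6 heavy atoms (4 carbon, 1 oxygen, 1 selenium; no ring) in place of a group of 6 heavy atoms (4 carbon, 1 sulfur, 1 bromine; no ring), on an aromatic carbon. Two things change at once: sulfur gives way to selenium in the chain, and the chain's bromine gives way to a hydroxyl.

For the measured compounds named here, only one measured step bears on this. The step of a 3.0-fold higher number from compound 1 to compound 2 (0.48 log units; beyond the scatter) exchanged selenium for sulfur in that chain and gave a modest, beyond-scatter rise. Compound 3 runs that exchange backwards, so a lower number is expected on that account. Nothing measured speaks to the swap of bromine for a hydroxyl, so the second half of the change is unanchored. Compound 3 is therefore expected to land near compound 1, at 0.3 ug/mL in this assay, within 0.08 ug/mL to 1.2 ug/mL, a step of a 2.0-fold lower number from compound 2 to compound 3 (0.30 log units; within the scatter), with the range widened to cover the unknown hydroxyl.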

Compound 3, concentration for 50% inhibition: 1.4 ug/mL
Compound 3: the middle estimate sits 4.7-fold (0.67 log units) below what was measured, outside the stated range (above it).
By their numbers in this assay, from the lowest: compound 1; then compound 2; then compound 3.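

In this assay, the exchange of bromo for hydroxy on the saturated chain carbon bound to a triple-bonded carbon, with selenium kept in place, gives a 7.0-fold higher number from compound 1 to compound 3 (0.85 log units; beyond the scatter), so this chain position is sensitive to that swap and the bromo-bearing compound holds the lower number. The combined change gives a 2.3-fold higher number from compound 2 to compound 3 (0.37 log units; beyond the scatter), which shows that bringing selenium back does not make up for the loss of bromo, even though selenium went with the lower number in a 3.0-fold higher number from compound 1 to compound 2 (0.48 log units; beyond the scatter). No measurement at hand explains why the hydroxy compound gives the higher number.

The compounds shown leave open whether bromo is specifically required, or whether chloro, a methoxy group or an amine on the same saturated chain carbon would keep the number low. They also leave open whether the exchange of bromo for hydroxy gives a step of similar size when sulfur rather than selenium links that chain to the core, and whether a longer chain would change the picture.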